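Swapping methoxy for chloro on the aryl of compound 2

The source may report more compounds than this note shows. Statements on the series, on what has been measured and on what is new or still open speak of the compounds shown alone.

Compound 2 `COc1ccc(-c2nc(SCC(=O)c3sc(-c4ccccc4)nc3C)nc(N)c2C#N)cc1` gives the highest number of the three measured in a functional assay on MCF7 cells (Homo sapiens) for antiproliferative activity, read by MTT assay, with a stated time of 48 h (a higher number here means a weaker inhibitor, a lower number a stronger inhibitor), namely 27200 nM. Compound 3 `COc1ccc(-c2nc(C)c(C(=O)CSc3nc(N)c(C#N)c(-c4ccc(OC)cc4)n3)s2)cc1` sits close by with 24300 nM, and compound 1 `Cc1nc(-c2ccc(Cl)cc2)sc1C(=O)CSc1nc(N)c(C#N)c(-c2ccc(Cl)cc2)n1` is the furthest away with 12500 nM. The step of a 1.1-fold lower number from compound 2 to compound 3 (0.05 log units; within the scatter) shows that adding a methoxy changes little. Compound 4 `Cc1nc(-c2ccccc2)sc1C(=O)CSc1nc(N)c(C#N)c(-c2ccc(Cl)cc2)n1` differs from compound 2 by chloro in place of methoxy on an aromatic carbon, taking 4-methoxyphenyl to 4-chlorophenyl. Within the data shown here, no measured pair shows this exact change, but compound 1 carries the same 4-chlorophenyl and returns a lower number than compound 2. Compound 4 is therefore expected to follow a modest step of a 1.8-fold lower number from compound 2 to compound 4 (0.26 log units; within the scatter) toward a lower number. Compound 4 is estimated at 15000 nM, with a range from 6000 nM to 40000 nM.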

Compound 4, half-maximal inhibitory concentration: 20200 nM
For compound 4 the middle estimate is 1.3-fold (0.13 log units) below the measured one; low and high end bracket the measured number.
By their numbers in this assay, from the lowest: compounds 1, 4, 3 and 2 (each within the scatter of the next, the first and the last beyond it).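

In this assay, chloro in place of methoxy on this ring gives a 1.3-fold lower number from compound 2 to compound 4 (0.13 log units; within the scatter), so the number does not separate the 4-methoxyphenyl from the 4-chlorophenyl form. Hydrogen in place of chloro on an aromatic carbon gives a 1.6-fold higher number from compound 1 to compound 4 (0.21 log units; within the scatter), so this single change also stays inside the usual spread. Nothing available bears on why these changes read this way. On these data alone, only methoxy and chloro are compared at this position, so whether an amine or a carboxylic acid there would give a step beyond the scatter remains open.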